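The compounds below may be only part of what the source reports. "The series", "measured", "known", "first", "only" and "open" are said of these compounds alone.

In a functional assay on MCF7 cells (Homo sapiens) for cytotoxicity, read by sulforhodamine B assay, with a stated time of 48 h (a lower number here means a stronger inhibitor, a higher number a weaker inhibitor), compound 1 (`COc1ccc(/C=C/C(=O)c2cccc(-c3ccc(F)cc3)c2)cc1`) gives 16400 nM, close to compound 2 (`COc1cccc(/C=C/C(=O)c2cccc(-c3cccc(F)c3)c2)c1OC`) at 11700 nM, a gap within the scatter, while compound 3 (`COc1ccc(/C=C/C(=O)c2cccc(-c3cccc(F)c3)c2)cc1`) gives 3080 nM. Compound 4 (`COc1ccc(/C=C/C(=O)c2cccc(-c3ccc(F)cc3)c2)cc1OC`) differs from compound 1 by methoxy in place of hydrogen on an aromatic carbon, ortho to a methoxy group. Among the compounds with values here, the one measured step, a 5.3-fold lower number from compound 1 to compound 3 (0.73 log units; beyond the scatter), swaps 4-fluorophenyl for 3-fluorophenyl and leaves the methoxy pattern untouched, so it bears only indirectly. Compound 2, which also carries two methoxy groups, gives 11700 nM despite having 3-fluorophenyl. No change beyond the scatter is therefore expected, with an estimated 1.2-fold lower number from compound 1 to compound 4 (0.07 log units; within the scatter). For compound 4 the expected value in this assay is 14000 nM, within an estimated range of 5000 nM to 40000 nM.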

Compound 4, half-maximal inhibitory concentration: 11600 nM
For compound 4 the middle estimate is 1.2-fold (0.08 log units) above the measured one; measured number inside the range.
By their numbers in this assay, from the lowest: compound 3; then compounds 4, 2 and 1 (each within the scatter of the next).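

In this assay methoxy in place of hydrogen, ortho to a methoxy group, gives a 1.4-fold lower number from compound 1 to compound 4 (0.15 log units; within the scatter) and so shows that this position on the 4-fluorophenyl series takes a second methoxy without a change beyond the scatter. Within the data shown here, this is the first step that reads the methoxy pattern directly, since the earlier step moved only the fluorine. No measured evidence on the reason for this flat result is at hand.

On these data alone, whether an amine, a carboxylic acid or a longer chain such as ethoxy would be equally flat at this position stays open. So does whether the same added methoxy would leave compound 3 unchanged.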